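The source may report more compounds than this note shows. Statements on the series, on what has been measured and on what is new or still open speak of the compounds shown alone.

Measured compounds in a functional assay on PC-3 cells (Homo sapiens) for inhibition, read by MTT assay, with a stated time of 48 h; on this read-out lower numbers stand for stronger inhibition of growth and higher numbers for weaker inhibition of growth:
- compound 1, `C#CCN(C)Cc1cccc(NC(=O)CCCCCC(=O)NO)c1`: 4630 nM
- compound 2, `C#CCN(C)Cc1ccc(NC(=O)CCC(=O)NO)cc1`: > 10000 nM
- compound 3, `C#CCN(C)Cc1ccc(NC(=O)CCCCC(=O)NO)cc1`: > 10000 nM

Compound 3 stands at a limit of this assay: it gives > 10000 nM, which is not a number. Compound 2 likewise gives only the limit > 10000 nM. Going by the values given here, the one step that connects two of the measured compounds, a step that the two limits leave unreadable from compound 2 to compound 3, is therefore unreadable in size, as both of its ends sit at the limit noted in the limit of > 10000 nM in this assay, at which 2 of the 3 values shown sit. Among the compounds with values here, compound 1, which carries a longer chain on a differently substituted core, is the only one of the three with a read number, 4630 nM; no single-point step joins it to compound 3, so its value is only context.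

The next compound, compound 4, `C#CCN(C)Cc1ccc(NC(=O)CCCCCCCC(=O)NO)cc1`, differs from compound 3 by 3-(hydroxycarbamoyl)propyl in place of hydroxycarbamoyl on a saturated chain carbon, four bonds along the chain from a carbonyl carbon. Within the data shown here, no measured step bears directly on a chain lengthening of this size, since the only step of that kind, from compound 2 to compound 3, cannot be read. In this assay the expectation for compound 4 rests on compound 1 having given a read value at 4630 nM with a longer chain. A move into readable numbers is therefore estimated for compound 4, of size an at least 2.8-fold lower number from compound 3 to compound 4 (0.45 log units; beyond the scatter). Compound 4 is estimated at 3500 nM, in the range 900 nM to 10000 nM.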

Compound 4, concentration for 50% growth inhibition: 7160 nM
Estimate against measurement, compound 4: 2.0-fold (0.31 log units) below; the range from low to high includes it.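

Compound 3 gives > 10000 nM in this assay and that value is a limit, not a number. Compound 4 gives 7160 nM as a read number, and the change to 3-(hydroxycarbamoyl)propyl, on a saturated chain carbon, four bonds along the chain from a carbonyl carbon, amounts to an at least 1.3-fold lower number from compound 3 to compound 4 (0.14 log units; that floor lies within the scatter) and nothing firmer can be said of its size. Among compounds 2, 3 and 4, only compound 4 reaches a read value, so this chain lengthening on the shared core can bring the series off the limit, yet the floor of the step does not by itself show a change beyond the usual scatter.

Open on the shared core is whether a still longer chain gives a lower number than compound 4, and whether a carboxylic acid in place of the hydroxycarbamoyl end keeps any read value. The step between the two shorter chains cannot be read, and the series still has only one read number on this core, with the rest at a limit: the limit of > 10000 nM in this assay, at which 2 of the 4 values shown sit.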